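Aryl variation on the acrylamide chain of the anilinoquinazoline series

The source may hold more compounds than are shown below. What is called first, only, known or untested is meant among the compounds shown, and "the series" means these compounds.

Measured compounds in a functional assay on A549 cells (Homo sapiens) for antiproliferative activity, read by MTT assay, with a stated time of 48 h; a lower number here means a stronger inhibitor, a higher number a weaker inhibitor:
compound 1 `O=C(/C=C/c1ccc(Br)cc1)Nc1ccc2ncnc(Nc3cccc(Cl)c3)c2c1` gives 1.86 ug/mL
compound 2 `COc1cccc(/C=C/C(=O)Nc2ccc3ncnc(Nc4cccc(Cl)c4)c3c2)c1` gives 2.58 ug/mL
compound 3 `Cc1ccc(/C=C/C(=O)Nc2ccc3ncnc(Nc4cccc(Cl)c4)c3c2)cc1` gives 6.03 ug/mL

Compound 3 stands highest of the three numbers in this assay; its nearest neighbour is compound 2, as a 2.3-fold higher number from compound 2 to compound 3 (0.37 log units; beyond the scatter) shows, and the furthest is compound 1, as a 3.2-fold higher number from compound 1 to compound 3 (0.51 log units; beyond the scatter) shows. Both changes exchange only the aryl group on the double-bonded chain carbon bound to a double-bonded chain carbon, with the shared core untouched. The change from compound 2 to compound 1 is not a single-place step and is read only from the two values, which are within the scatter of each other, as a 1.4-fold higher number from compound 1 to compound 2 (0.14 log units; within the scatter) confirms.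

Compound 4 `O=C(/C=C/c1cccc2ccccc12)Nc1ccc2ncnc(Nc3cccc(Cl)c3)c2c1` is not yet measured. It differs from compound 3 by naphthalen-1-yl in place of 4-methylphenyl on a double-bonded chain carbon bound to a double-bonded chain carbon. Among the compounds with values here, the steps that bear on it are those at the same place: moving from the 4-methylphenyl of compound 3 to either other aryl group lowered the number by a modest margin. A step of similar size and direction is therefore expected, given a 3.2-fold higher number from compound 1 to compound 3 (0.51 log units; beyond the scatter) and a 2.3-fold higher number from compound 2 to compound 3 (0.37 log units; beyond the scatter); a result within the scatter is also possible. For compound 4 in this assay the number expected is 2.5 ug/mL, with a range from 1 ug/mL to 6 ug/mL, corresponding to an expected step of a 2.4-fold lower number from compound 3 to compound 4 (0.38 log units; beyond the scatter).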

Compound 4, half-maximal inhibitory concentration: 1.49 ug/mL
Compound 4: the middle estimate sits 1.7-fold (0.22 log units) above what was measured, within the range that was stated.
By their numbers in this assay, from the lowest: compounds 4, 1 and 2 (each within the scatter of the next); then compound 3.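

In this assay the position on a double-bonded chain carbon bound to a double-bonded chain carbon accepts naphthalen-1-yl, with its 2 six-membered aromatic rings, in place of the single ring of 4-methylphenyl: a 4.0-fold lower number from compound 3 to compound 4 (0.61 log units; beyond the scatter) confirms that this change separates the pair beyond the scatter. The larger aryl group does not set compound 4 apart from the other two aryl compounds, since a 1.7-fold lower number from compound 2 to compound 4 (0.24 log units; within the scatter) and a 1.2-fold lower number from compound 1 to compound 4 (0.10 log units; within the scatter) both lie within the scatter, leaving compound 3 as the only one of the four that stands apart, as the weakest inhibitor. Nothing available accounts for the position of compound 3 or for the level values of the other three.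

As far as these compounds go, whether this position needs an aromatic ring at all remains open, and a saturated cyclohexyl group or a chain ending in a carboxylic acid or an amine would test that. The aryl groups shown also carry no ring nitrogen, so a pyridinyl group at the same place would show whether an all-carbon aromatic ring is required.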